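The source may report more compounds than this note shows. Statements on the series, on what has been measured and on what is new or still open speak of the compounds shown alone.

Measured compounds in a functional assay on NCI-H1581 cells (Homo sapiens) for inhibition, read by MTT assay, with a stated time of 48 h, tested at 10 uM; on this read-out higher numbers stand for more inhibition at the one concentration tested (going by the name of the read-out) and lower numbers for less inhibition:
- compound 1, `Cc1ccc(Nc2cc(NC(=O)Nc3c(Cl)cccc3Cl)ncn2)cc1C`, gives 73.3%
- compound 2, `COc1cc(NC(=O)Nc2cc(Nc3ccc(F)c(Cl)c3)ncn2)cc(OC)c1`, gives 53%
- compound 3, `COc1ccc(Nc2cc(NC(=O)Nc3c(Cl)cccc3Cl)ncn2)cc1C`, gives 45.1%

Compound 2 stands second highest of the three; its number and that of compound 3 lie within the scatter, while compound 1 stands beyond the scatter above it. The unmeasured compound 4, `COc1cc(NC(=O)Nc2cc(Nc3ccc(Br)cc3OC)ncn2)cc(OC)c1`, differs from compound 2 by 4-bromo-2-methoxyphenyl in place of 3-chloro-4-fluorophenyl on a nitrogen on an aromatic ring. Within the data shown here, the only measured step on that ring is a number 28.2 percentage points lower from compound 1 to compound 3 (beyond the scatter), a modest loss on a change to the substitution of the same aryl. It bears on compound 4 loosely, since both changes alter that ring's substituents and a methoxy enters in both. A small to modest drop in this assay is expected, a number 8 percentage points lower from compound 2 to compound 4 (within the scatter). Compound 4 is therefore estimated at 45%, within 25% to 65%.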

Compound 4, a percentage reported as inhibition, at one concentration (the size of the read-out at that concentration, not a potency): 20.1%
Compound 4: middle estimate off by 24.9 percentage points, on the high side; the whole stated range lies above it.
By their numbers in this assay, from the lowest: compound 4; then compounds 3 and 2 (each within the scatter of the next); then compound 1.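

In this assay, changing the whole aryl on the nitrogen, with the rest of compound 2 held fixed, gives a number 32.9 percentage points lower from compound 2 to compound 4 (beyond the scatter) and so a large loss, showing that this position is sensitive to the exchange of 3-chloro-4-fluorophenyl for 4-bromo-2-methoxyphenyl. The earlier step, a number 28.2 percentage points lower from compound 1 to compound 3 (beyond the scatter), involved one substituent only and a different urea partner, so it did not show this. No evidence on the origin of the loss is available.

Going by these compounds, the bromine and the methoxy enter together, so their separate contributions remain open. On these data alone, how an aryl bearing a dimethylamino group or a carboxylic acid would behave at this position also remains open.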